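The source may hold more compounds than are shown below. What is called first, only, known or untested is meant among the compounds shown, and "the series" means these compounds.

Three compounds share one core and differ only in the group on a saturated chain carbon bound to a carbonyl carbon. Compound 1 `CC[C@H](C)[C@H](NCC(=O)NNC(=O)COc1ccc(-c2nc3ccccc3s2)cc1OC)C(=O)O` gives 1710 nM in a functional assay on MCF7 cells (Homo sapiens) for inhibition, read by MTT assay, with a stated time of 3 days; a higher number here means a weaker inhibitor, a lower number a stronger inhibitor. Compound 2 `COc1cc(-c2nc3ccccc3s2)ccc1OCC(=O)NNC(=O)CN(C(C)=O)[C@@H](CS)C(=O)O` gives 1750 nM in this assay, and compound 3 `CCOC(=O)[C@H](CS)N(CC(=O)NNC(=O)COc1ccc(-c2nc3ccccc3s2)cc1OC)C(C)=O` gives 1890 nM. Compound 2 thus sits among three numbers that all lie within the scatter of one another: the step of a 1.0-fold higher number from compound 1 to compound 2 (0.01 log units; within the scatter) and the step of a 1.1-fold higher number from compound 2 to compound 3 (0.03 log units; within the scatter) are both too small to count as real change, as is a 1.1-fold higher number from compound 1 to compound 3 (0.04 log units; within the scatter).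

Compound 4 `CCOC(=O)[C@H](CS(=O)(=O)O)NCC(=O)NNC(=O)COc1ccc(-c2nc3ccccc3s2)cc1OC` has not yet been measured. It differs from compound 2 in this way: (1-(ethoxycarbonyl)-2-sulfoethyl)amino in place of acetyl(1-carboxy-2-sulfanylethyl)amino on a saturated chain carbon bound to a carbonyl carbon. The two measured steps at this same place, a 1.0-fold higher number from compound 1 to compound 2 (0.01 log units; within the scatter) and a 1.1-fold higher number from compound 2 to compound 3 (0.03 log units; within the scatter), bear on it directly, and neither moved the number beyond the scatter. A step of no more than the scatter is therefore expected from compound 2 to compound 4, a 1.0-fold higher number from compound 2 to compound 4 (0.01 log units; within the scatter), in no firm direction. Compound 4 is estimated to give 1800 nM in this assay, within a range of 900 nM to 3800 nM.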

Compound 4, half-maximal inhibitory concentration: 1990 nM
Compound 4: the middle estimate sits 1.1-fold (0.04 log units) below what was measured; the measured number falls inside the stated range.
By their numbers in this assay, from the lowest: compounds 1, 2, 3 and 4 (each within the scatter of the next).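

Even a bigger swap at this position leaves the number in this assay within the scatter: the (1-(ethoxycarbonyl)-2-sulfoethyl)amino group brings in a sulfo group where a sulfanyl stood and drops the acetyl, yet the result is only a small step (a 1.1-fold higher number from compound 2 to compound 4 (0.06 log units; within the scatter)). The same holds against the ethyl ester that keeps its acetyl and sulfanyl (a 1.1-fold higher number from compound 3 to compound 4 (0.02 log units; within the scatter)) and against the group from compound 1 (a 1.2-fold higher number from compound 1 to compound 4 (0.07 log units; within the scatter)), so all four groups on this saturated chain carbon bound to a carbonyl carbon read alike here. Nothing at hand explains why the number stays so flat at this position.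

The groups shown are all open chains, so it stays open whether a phenyl ring or a free primary amine at this place would move the number beyond the scatter. Changes elsewhere on the shared core also remain untested by these compounds.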